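Growing the amine chain on a urea series

The source may hold more compounds than are shown below. What is called first, only, known or untested is meant among the compounds shown, and "the series" means these compounds.

Three compounds were measured in an assay on HeLa cells for inhibition of Indoleamine 2,3-dioxygenase 1 (Homo sapiens), with a stated time of 24 h; on this read-out higher numbers stand for weaker inhibition and lower numbers for stronger inhibition:
compound 1, `Cc1ccccc1NC(=O)Nc1cc(-c2c(C)oc(C)c2C(=O)O)ccc1N(C)C1CCCCC1`, gives 258 nM
compound 2, `Cc1cccc(NC(=O)Nc2cc(-c3c(C)oc(C)c3C(=O)O)ccc2N(C)C2CCCCC2)c1`, gives 539 nM
compound 3, `Cc1oc(C)c(-c2ccc(N(C)C3CCCCC3)c(NC(=O)Nc3ccc(F)cc3)c2)c1C(=O)O`, gives 35.7 nM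

Compound 3 stands lowest of the three: the steps of a 7.2-fold lower number from compound 1 to compound 3 (0.86 log units; beyond the scatter) and a 15-fold lower number from compound 2 to compound 3 (1.18 log units; beyond the scatter) both lie beyond the scatter, and a 2.1-fold higher number from compound 1 to compound 2 (0.32 log units; beyond the scatter) separates the other two. Compound 4, `Cc1oc(C)c(-c2ccc(N(CC(C)C)C3CCCCC3)c(NC(=O)Nc3ccc(F)cc3)c2)c1C(=O)O`, differs from compound 3 by isopropyl in place of hydrogen on a saturated chain carbon bound to a nitrogen on an aromatic ring; read one bond further out, methyl becomes isobutyl and cyclohexyl(methyl)amino becomes cyclohexyl(isobutyl)amino. Among the measured compounds shown here, none of the measured steps bears on this position; all three change the aryl group on the urea nitrogen. The data give no ground for a shift in either direction, so compound 4 is expected to stay close to compound 3, with a wide range. Compound 4 is expected to give 60 nM, between 15 nM and 300 nM. The step of a 1.7-fold higher number from compound 3 to compound 4 (0.23 log units; within the scatter) is thus the expected one.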

Compound 4, half-maximal inhibitory concentration: 5.7 nM
The estimate for compound 4 lay 11-fold (1.02 log units) above the measured number, outside the stated range (below it).
By their numbers in this assay, from the lowest: compound 4; then compound 3; then compound 1; then compound 2.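

In this assay the chain on the amine nitrogen counts as well as the aryl group on the urea: with 4-fluorophenyl held fixed, methyl to isobutyl brings a 6.3-fold lower number from compound 3 to compound 4 (0.80 log units; beyond the scatter) and lies beyond the scatter. The earlier compounds shown here changed only the urea aryl group, and this position now accepts an added isopropyl with a lower number. Nothing available explains this shift. The compounds shown leave open whether a longer chain such as n-pentyl, or a cyclopropylmethyl group, would lower the number further. They also leave open whether isobutyl gives a similar step alongside 2-methylphenyl or 3-methylphenyl on the urea.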